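Replacing the 3-carbamoylphenyl group of compound 2

The compounds below may be only part of what the source reports. "The series", "measured", "known", "first", "only" and "open" are said of these compounds alone.

Measured so far in an ADME assay (liver) for metabolic stability, with Liver microsome (Rattus norvegicus) as the target, using microsomes and NADPH, with a stated time of 30 min, tested at 1 uM (a higher number here means faster removal of the compound, a lower number slower removal), for this series:
- compound 1 `CC(C)(C)n1cc(-c2cc(C(O)(C(F)(F)F)C(F)(F)F)cnc2N2CCN(S(=O)(=O)c3ccc(N)nc3)CC2)cn1` gives 459 mL.min-1.g-1
- compound 2 `NC(=O)c1cccc(-c2cc(C(O)(C(F)(F)F)C(F)(F)F)cnc2N2CCN(S(=O)(=O)c3ccc(N)nc3)CC2)c1` gives 63 mL.min-1.g-1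

Compound 2 holds the lower of the two numbers. Compound 3 `Nc1ccc(S(=O)(=O)N2CCN(c3ncc(C(O)(C(F)(F)F)C(F)(F)F)cc3-c3ccncc3)CC2)cn1` carries pyridin-4-yl in place of 3-carbamoylphenyl on an aromatic carbon. Going by the values given here, the only measured step at this place is a 7.3-fold lower number from compound 1 to compound 2 (0.86 log units; beyond the scatter) and is beyond the scatter, but it starts from 1-(tert-butyl)-1H-pyrazol-4-yl, which compound 3 does not carry. The expected step in this assay is a 1.1-fold higher number from compound 2 to compound 3 (0.05 log units; within the scatter) and stays within the scatter, with no firm direction. For compound 3 the estimate is 70 mL.min-1.g-1 (25 mL.min-1.g-1 to 200 mL.min-1.g-1).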

Compound 3, intrinsic clearance in microsomes: 31 mL.min-1.g-1
Compound 3: the middle estimate sits 2.3-fold (0.35 log units) above what was measured, within the range that was stated.
By their numbers in this assay, from the lowest: compound 3; then compound 2; then compound 1.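

At this aromatic carbon, pyridin-4-yl gives a 2.0-fold lower number from compound 2 to compound 3 (0.31 log units; beyond the scatter) in this assay, so a low number here does not depend on the carbamoyl group or its hydrogen-bond donor. Against 1-(tert-butyl)-1H-pyrazol-4-yl the change is larger, a 15-fold lower number from compound 1 to compound 3 (1.17 log units; beyond the scatter), the widest step at this position so far. No measurement at hand accounts for either step.

As far as these compounds go, whether the ring nitrogen of pyridin-4-yl matters remains open, and a plain phenyl or pyridin-3-yl at this carbon would test it. From the compounds shown here alone, how a carboxylic acid or a small amine would behave here is also open.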